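The source may hold more compounds than are shown below. What is called first, only, known or untested is meant among the compounds shown, and "the series" means these compounds.

Measured so far in an assay on microsomes from liver for inhibition of 3-hydroxy-3-methylglutaryl-coenzyme A reductase (Rattus norvegicus); on this read-out lower numbers stand for stronger inhibition and higher numbers for weaker inhibition:

compound 1 `Cc1ccccc1CNC(=O)c1nn(-c2ccc(F)cc2)c(OC[C@@H](O)C[C@@H](O)CC(=O)O)c1C(C)C`: 17 nM
compound 2 `COc1ccccc1CNC(=O)c1nn(-c2ccc(F)cc2)c(OC[C@@H](O)C[C@@H](O)CC(=O)O)c1C(C)C`: 22 nM
compound 3 `Cc1cccc(CN(C)C(=O)c2nn(-c3ccc(F)cc3)c(OC[C@@H](O)C[C@@H](O)CC(=O)O)c2C(C)C)c1`: 37 nM

Among the compounds with values here, compound 3 carries the highest number of the three, but its distance to compound 2 is within the scatter; only the step of a 2.2-fold higher number from compound 1 to compound 3 (0.34 log units; beyond the scatter) is beyond it, and that one is modest. The step of a 1.7-fold higher number from compound 2 to compound 3 (0.23 log units; within the scatter) shows no reliable difference.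

Compound 4 `CC(C)c1c(C(=O)N(C)Cc2ccc(F)c(F)c2)nn(-c2ccc(F)cc2)c1OC[C@@H](O)C[C@@H](O)CC(=O)O` follows from compound 3 by one change: 3,4-difluorophenyl in place of 3-methylphenyl on a saturated chain carbon bound to an amide-type nitrogen. Within the data shown here, no measured step touches this ring in the same way. The closest comparison is the exchange of one substituent on an aromatic carbon, a 1.3-fold higher number from compound 1 to compound 2 (0.11 log units; within the scatter), which lies within the scatter. The steps of a 2.2-fold higher number from compound 1 to compound 3 (0.34 log units; beyond the scatter) and a 1.7-fold higher number from compound 2 to compound 3 (0.23 log units; within the scatter) alter the amide nitrogen and the ring substituent together and are therefore not clean guides. From these three compounds the benzyl ring substituent appears to be tolerated without large effect, so in this assay the step from compound 3 to compound 4 is expected to stay within the scatter, with no fixed direction, a 1.1-fold higher number from compound 3 to compound 4 (0.03 log units; within the scatter). From the compounds shown here alone, the estimate for compound 4 is therefore 40 nM, with a range from 15 nM to 110 nM, the width reflecting that the entering ring is untested.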

Compound 4, half-maximal inhibitory concentration: 5.7 nM
Compound 4: middle estimate off by 7.0-fold (0.85 log units), on the high side; measured number below the stated range.
By their numbers in this assay, from the lowest: compound 4; then compounds 1, 2 and 3 (each within the scatter of the next, the first and the last beyond it).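

In this assay, within the data shown here, the ring on the saturated chain carbon bound to the amide-type nitrogen is a position that can move the number well beyond the scatter (a 6.5-fold lower number from compound 3 to compound 4 (0.81 log units; beyond the scatter)), which the earlier compounds, all close to one another, did not show. The whole amino group on the carbonyl carbon gives the same direction against the two compounds that keep the amide hydrogen (a 3.9-fold lower number from compound 2 to compound 4 (0.59 log units; beyond the scatter); a 3.0-fold lower number from compound 1 to compound 4 (0.47 log units; beyond the scatter)), so compound 4 is the strongest inhibitor of the four, and the methyl on the amide nitrogen, shared by compound 3 and compound 4, does not by itself keep the number high. Nothing in the available data accounts for this gain.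

Open, from the compounds shown here alone, is what the 3,4-difluorobenzyl group gives on an amide that keeps the amide hydrogen, as the pairs with compound 1 and compound 2 change the methyl and the ring together. Also open, going by these compounds, is whether a single fluorine, two chlorines or a pyridine ring in place of the 3,4-difluorophenyl would hold a number of this order.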